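Ethyl to Methylsulfanyl on the Core of Compound 2

The source may report more compounds than this note shows. Statements on the series, on what has been measured and on what is new or still open speak of the compounds shown alone.

Going by the values given here, compound 2 `CCc1cnc(-c2nn(Cc3ccccc3F)c3ncccc23)nc1N` was tested in a functional assay (aorta) with Oryctolagus cuniculus as the target (on this read-out higher numbers stand for weaker inhibition and lower numbers for stronger inhibition), where compound 2 gives 272000 nM; that is its only number, and one further entry yielded no number at all. Compound 1 `OCc1ccc(-c2nn(Cc3ccccc3F)c3ccccc23)o1` is built differently, and in this assay compound 1 gives 4900 nM; 4900 nM (2 entries). Compound 3 `CSc1cnc(-c2nn(Cc3ccccc3F)c3ncccc23)nc1N` is not yet measured. It differs from compound 2 in one place: methylsulfanyl in place of ethyl on an aromatic carbon. Among the compounds with values here, no measured pair shows this change, so the step of a 1.4-fold lower number from compound 2 to compound 3 (0.13 log units; within the scatter) is expected to stay within the scatter, with no direction favoured. For compound 3 the estimate is 200000 nM, within 60000 nM to 700000 nM.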

Compound 3, half-maximal inhibitory concentration: 243000 nM
Beside the measured number, compound 3's estimate is 1.2-fold (0.08 log units) below it; the measured number falls inside the stated range.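

In this assay, going by these compounds alone, methylsulfanyl in place of ethyl on the aromatic carbon ortho to an amino group gives a 1.1-fold lower number from compound 2 to compound 3 (0.05 log units; within the scatter) in the first measured pair at this position. The swap keeps the count of heavy atoms and adds a hydrogen-bond acceptor, yet the two compounds stay within the scatter of each other. No evidence here accounts for this result. On these data alone, what remains open is whether an amine, a carboxylic acid or a longer chain at this position would read any differently from ethyl and methylsulfanyl.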